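Amide nitrogen substituent: benzyl against aryl in the series

The compounds below may be only part of what the source reports. "The series", "measured", "known", "first", "only" and "open" are said of these compounds alone.

Compound 3 `COc1ccc2c(=O)c(/C=C/C(=O)NCc3ccccc3)coc2c1` holds the only full number shown: in a functional assay on Huh-7 cells (Homo sapiens) for inhibition, read by MTT assay, with a stated time of 48 h (on this read-out higher numbers stand for weaker inhibition and lower numbers for stronger inhibition), compound 3 gives 13600 nM. Compound 1 `COc1ccc2c(=O)c(/C=C/C(=O)Nc3cccc(Cl)c3)coc2c1` reaches only a limit of this assay, > 100000 nM. Compound 2 `COc1ccc2c(=O)c(/C=C/C(=O)Nc3ccc(C)cc3)coc2c1` likewise sits at a limit, > 100000 nM. The step that the two limits leave unreadable from compound 1 to compound 2 is therefore unreadable. The steps of an at least 7.3-fold lower number from compound 1 to compound 3 (0.86 log units; beyond the scatter) and an at least 7.3-fold lower number from compound 2 to compound 3 (0.86 log units; beyond the scatter) point the same way, both starting from the limit of > 100000 nM in this assay, at which 2 of the 3 values shown sit. Compound 4 `COc1ccc2c(=O)c(/C=C/C(=O)Nc3cccc(C)c3)coc2c1` differs from compound 3 by 3-methylphenyl in place of benzyl on an amide-type nitrogen. This runs those two steps backwards, so a higher number is expected for compound 4, with a fair chance that compound 4 again reaches only a limit. For compound 4 the expected step is a 7.4-fold higher number from compound 3 to compound 4 (0.87 log units; beyond the scatter), giving an estimate of 100000 nM within 30000 nM to 300000 nM.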

Compound 4, half-maximal inhibitory concentration: 15500 nM
Beside the measured number, compound 4's estimate is 6.5-fold (0.81 log units) above it; the measured number lies below the stated range.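

In this assay, an aryl group on the amide-type nitrogen does not by itself rule out a measurable value: a 1.1-fold higher number from compound 3 to compound 4 (0.06 log units; within the scatter), so 3-methylphenyl and benzyl cannot be told apart here. Among the aryl amides the choice of ring group now matters, with an at least 6.4-fold lower number from compound 2 to compound 4 (0.80 log units; beyond the scatter) and an at least 6.4-fold lower number from compound 1 to compound 4 (0.80 log units; beyond the scatter). Both of these steps start from a limit of the assay, not from a number: the limit of > 100000 nM in this assay, at which 2 of the 4 values shown sit.

Going by these compounds, how large either step truly is stays open. Also open, on these data alone, is whether 3-methoxyphenyl or 2-phenylethyl on this nitrogen would give a lower number than compound 3 and compound 4.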